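The compounds below may be only part of what the source reports. "The series", "measured", "known", "first", "only" and "open" are said of these compounds alone.

Three compounds have been measured in an ADME assay on the whole organism with Oryza sativa as the target, tested at 0.1 uM; on this read-out higher numbers stand for a weaker effect at the one concentration tested and lower numbers for a stronger effect:

compound 1, `C[C@H](NC(=O)Nc1ccccc1Cl)c1ccccc1`: 99%
compound 2, `C[C@H](NC(=O)Nc1cccc(Cl)c1)c1ccccc1`: 103%
compound 3, `C[C@@H](NC(=O)Nc1cc(Cl)ccc1Cl)c1ccccc1`: 99%

Compound 3 stands level with compound 1 at the digits given, and its nearest neighbour among the measured numbers is compound 1, with no change at the digits shown. The number furthest from it is that of compound 2, which lies higher, still within the scatter of this kind of measurement. All three read-outs therefore sit close together near the level at which the test shows essentially no effect at the single concentration tested, and nothing among them can be called stronger or weaker than another.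

The piece now follows the step to compound 4, `C[C@H](NC(=O)Nc1cc(Cl)ccc1Cl)c1ccccc1`, which has not yet been measured in this assay. The change from compound 3 is the two compounds have the same atoms and bonds and differ only in configuration as drawn: 1 of 1 stereo elements differ; a stereocentre at a saturated chain carbon is drawn R in compound 3 and S in compound 4. Going by the values given here, no step between measured compounds is available that would show what such a change does here.

Given that all three measured numbers lie within the scatter of one another, compound 4 is expected to give a read-out of the same kind, with a step of about a number 1 percentage points higher from compound 3 to compound 4 (within the scatter), that is, none beyond the scatter. The estimate for compound 4 in this assay is 100%, with a range from 90% to 110%.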

Compound 4, a percentage reported as activity, at one concentration (the size of the read-out at that concentration, not a potency): 100%
Beside the measured number, compound 4's estimate shows no gap at the digits printed; low and high end bracket the measured number.
By their numbers in this assay, from the lowest: compounds 1, 3, 4 and 2 (each within the scatter of the next).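

In this assay, going by these compounds alone, the pair gives the first reading of a change in configuration alone, at the saturated chain carbon drawn R in compound 3 and S in compound 4, and the step is a number 1 percentage points higher from compound 3 to compound 4 (within the scatter). Chloro in place of hydrogen on an aromatic carbon can also now be read for the first time, in two steps: one is a number 3 percentage points lower from compound 2 to compound 4 (within the scatter) and the other is a number 1 percentage points higher from compound 1 to compound 4 (within the scatter), so neither addition separates the compounds in this read-out. The stereochemical comparison is a clean one, with no second structural change beside it: the fact that compounds 3 and 4 differ only in the configuration as drawn

All four compounds remain within the scatter of one another in this assay, so these steps leave open whether configuration or a further chloro would matter in a compound that gives a clear effect. The compounds shown also leave open what a methoxy group, an amine or a carboxylic acid in place of chloro on an aromatic carbon would do to the read-out.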